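Swapping Sulfide for Sulfoxide on the Shorter Analogue

The compounds below may be only part of what the source reports. "The series", "measured", "known", "first", "only" and "open" are said of these compounds alone.

Compound 3 `Nc1cccc(SCc2ccc(OCCCCCCCCc3ccccc3)c(/C=C/C(=O)O)n2)c1` gives 36 nM in an assay for binding affinity to leukotriene B4 receptor 1 (Homo sapiens) (on this read-out higher numbers stand for weaker inhibition and lower numbers for stronger inhibition), the highest of the three numbers in hand. Compound 1 `COc1ccc(CCCCCCCCOc2ccc(CSc3cccc(N)c3)nc2/C=C/C(=O)O)cc1` gives 34 nM, and the difference is a 1.1-fold higher number from compound 1 to compound 3 (0.02 log units; within the scatter). Compound 2 `COc1ccc(CCCCCCCCOc2ccc(C[S+]([O-])c3cccc(N)c3)nc2/C=C/C(=O)O)cc1` gives 4.7 nM. Compound 4 `Nc1cccc([S+]([O-])Cc2ccc(OCCCCCCCCc3ccccc3)c(/C=C/C(=O)O)n2)c1` has not yet been measured and differs from compound 3 in one place: a group of 9 heavy atoms (6 carbon, 1 nitrogen, 1 oxygen, 1 sulfur; one six-membered aromatic ring of carbon only) in place of a group of 8 heavy atoms (6 carbon, 1 nitrogen, 1 sulfur; one six-membered aromatic ring of carbon only), on a saturated chain carbon bound to an aromatic carbon. The same change has been made once before, from compound 1 to compound 2, where the result was a 7.2-fold lower number from compound 1 to compound 2 (0.86 log units; beyond the scatter). Compound 4 is therefore expected to show a 7.2-fold lower number from compound 3 to compound 4 (0.86 log units; beyond the scatter). The estimate for compound 4 in this assay is 5 nM, with a likely range from 2 nM to 13 nM.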

Compound 4, inhibition constant: 11 nM
For compound 4 the middle estimate is 2.2-fold (0.34 log units) below the measured one, within the range that was stated.
By their numbers in this assay, from the lowest: compound 2; then compound 4; then compounds 1 and 3 (each within the scatter of the next).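

In this assay the sulfoxide in place of the sulfide lowers the number on a second core as well, a 3.3-fold lower number from compound 3 to compound 4 (0.51 log units; beyond the scatter), so the gain is not confined to the methoxy-bearing core, and the two gains agree: the same change on two cores in this assay, a 7.2-fold lower number (0.86 log units; beyond the scatter) from compound 1 to compound 2 and a 3.3-fold lower number (0.51 log units; beyond the scatter) from compound 3 to compound 4, 2.2-fold (0.34 log units) apart, within the scatter of two such steps.

Among the sulfoxides, hydrogen in place of methoxy gives a 2.3-fold higher number from compound 2 to compound 4 (0.37 log units; beyond the scatter), a step beyond the scatter that the sulfides did not show, yet the two steps still agree: the same change on two cores in this assay, a 1.1-fold higher number (0.02 log units; within the scatter) from compound 1 to compound 3 and a 2.3-fold higher number (0.37 log units; beyond the scatter) from compound 2 to compound 4, 2.2-fold (0.34 log units) apart, within the scatter of two such steps.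

Still open, from the compounds shown here alone, is whether a sulfone, with a second oxygen on the sulfur, would lower the number further, and whether an amide in place of the amine would keep the gain.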